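Methoxy for chloro on a fused aromatic ring

The source may hold more compounds than are shown below. What is called first, only, known or untested is meant among the compounds shown, and "the series" means these compounds.

Compound 1 `CCOC(=O)C1=C(C)NC(=O)NC1c1cc(=O)oc2ccc(C)cc12`: 80%
Compound 2 `CCOC(=O)C1=C(C)NC(=O)NC1c1cc(=O)oc2ccc(Cl)cc12`: no result reported

In an assay on isolated protein for inhibition of matrix metalloproteinase-9 (Homo sapiens), with a stated time of 30 min, tested at 500 ug/L (a higher number here means more inhibition at the concentration tested (going by the name of the read-out), a lower number less inhibition), compound 1 gives 80%. Going by these compounds, compound 2 gives no result reported in this assay, so its standing is unknown. Compound 3 `CCOC(=O)C1=C(C)NC(=O)NC1c1cc(=O)oc2ccc(OC)cc12` differs from compound 2 by methoxy in place of chloro on an aromatic carbon. With no measured step between these compounds, the size and direction of the change in this assay cannot be told from the data shown. Compound 1 offers the only anchor, with a comparable core. Compound 3 is expected to give about 70%, in a range from 40% to 95%.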

Compound 3, a percentage reported as inhibition, at one concentration (the size of the read-out at that concentration, not a potency): 85%
Beside the measured number, compound 3's estimate is 15 percentage points below it; low and high end bracket the measured number.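

In this assay, methoxy in place of methyl on the same aromatic carbon gives a number 5 percentage points higher from compound 1 to compound 3 (within the scatter) and so the two groups cannot be told apart here. This position therefore takes a group with one more heavy atom and a hydrogen-bond acceptor, with no difference beyond the scatter.

Compound 2 has no result, so the swap of chloro for methoxy cannot be read. Whether an amine or a longer chain on this carbon would give a similar reading stays open, and no measurement shown offers a reason for this result.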